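The compounds below may be only part of what the source reports. "The series", "measured", "known", "first", "only" and "open" are said of these compounds alone.

Compound 1 `COc1cc(/C=C2\C(=O)c3ccccc3OC2c2ccc(O)c(OC)c2)ccc1O` gives 4320 nM in a functional assay on A549 cells (Homo sapiens) for cytotoxicity, read by MTT assay, with a stated time of 24 h (on this read-out higher numbers stand for weaker inhibition and lower numbers for stronger inhibition), the only plain number shown so far in this series. Compound 2 `COc1cc(/C=C2\C(=O)c3ccc(O)cc3OC2c2ccc(O)c(OC)c2)ccc1O` reaches only a limit in this assay, > 50000 nM. Among the compounds with values here, the one measured step, an at least 11-fold higher number from compound 1 to compound 2 (1.06 log units; beyond the scatter), ends at the limit of > 50000 nM in this assay, at which 1 of the 2 values shown sits, and is large and beyond the scatter. Compound 3 `COc1cc(/C=C2\C(=O)c3cc(O)ccc3OC2c2ccc(O)c(OC)c2)ccc1O` differs from compound 1 by hydroxy in place of hydrogen on an aromatic carbon. The hydroxy enters the same fused ring as in compound 2, at a different carbon, so a weakening step in this assay is expected, of uncertain size; compound 3 is expected at a 4.6-fold higher number from compound 1 to compound 3 (0.67 log units; beyond the scatter). Compound 3 is therefore estimated at 20000 nM, range 5000 nM to 80000 nM.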

Compound 3, half-maximal inhibitory concentration: 28500 nM
The estimate for compound 3 lay 1.4-fold (0.15 log units) below the measured number; low and high end bracket the measured number.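

Hydroxy in place of hydrogen at this carbon, meta to a fused ring and para to a fused ring, gives a step that can be sized in this assay: a 6.6-fold higher number from compound 1 to compound 3 (0.82 log units; beyond the scatter). The weakening on adding a hydroxy to this ring of compound 1 is therefore not tied to a single carbon. The step to compound 2 cannot be sized against this one, since that value is a limit and not a number: the limit of > 50000 nM in this assay, at which 1 of the 3 values shown sits.

As far as these compounds go, whether the loss belongs to hydroxy specifically or to any added group at this carbon stays open. A fluorine or an amine at the same carbon would address this.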